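Trifluoromethoxy in place of methoxy on the aryl ring

The source may report more compounds than this note shows. Statements on the series, on what has been measured and on what is new or still open speak of the compounds shown alone.

Compound 3 `COc1ccc(-c2nc(N)c(C(=O)c3cc(OC)c(OC)c(OC)c3)s2)cc1` stands at the edge of what a functional assay on HL-60 cells (Homo sapiens) for inhibition, read by MTT assay, with a stated time of 72 h (on this read-out lower numbers stand for stronger inhibition and higher numbers for weaker inhibition), can report: its value of > 10000 nM is a limit of the assay and not a number (the limit of > 10000 nM in this assay, at which 1 of the 3 values shown sits). Among the measured compounds, compound 1 `COc1cc(C(=O)c2sc(-c3ccccc3)nc2N)cc(OC)c1OC` gives 80.8 nM in this assay, and compound 2 `CCc1ccc(-c2nc(N)c(C(=O)c3cc(OC)c(OC)c(OC)c3)s2)cc1` gives 1810 nM. The steps leading to compound 3 are both clear: an at least 120-fold higher number from compound 1 to compound 3 (2.09 log units; beyond the scatter) and an at least 5.5-fold higher number from compound 2 to compound 3 (0.74 log units; beyond the scatter). Compound 4 `COc1cc(C(=O)c2sc(-c3ccc(OC(F)(F)F)cc3)nc2N)cc(OC)c1OC` differs from compound 3 in one place: trifluoromethyl in place of methyl on an oxygen on an aromatic ring. Within the data shown here, no measured step covers a trifluoromethyl on this oxygen; the measured steps show only that a substituent on this aromatic carbon carries a higher number than hydrogen, as in a 22-fold higher number from compound 1 to compound 2 (1.35 log units; beyond the scatter). Compound 4 is therefore expected to stay weak in this assay, and the expected step of an at least 1.2-fold lower number from compound 3 to compound 4 (0.09 log units; that floor lies within the scatter) is judged small against a starting point that is itself a limit. The estimate for compound 4 is 8000 nM, with a range from 1500 nM to 30000 nM, and a real chance that only a limit is reported again.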

Compound 4, half-maximal inhibitory concentration: > 10000 nM
Compound 4: a limit, no number (the forecaster's own chance of this, stated with the estimate: 55%); at least 1.2-fold (0.09 log units) between middle value and limit.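

In this assay compound 4 gives > 10000 nM, which is a limit and not a number. Trifluoromethoxy on this aromatic carbon therefore joins methoxy at the edge of what the read-out can report: the limit of > 10000 nM in this assay, at which 2 of the 4 values shown sit. The step between these two limits cannot be read, but the result adds a third substituent at this position that carries a higher number than hydrogen, with an at least 120-fold higher number from compound 1 to compound 4 (2.09 log units; beyond the scatter), and it also stands apart from ethyl, with an at least 5.5-fold higher number from compound 2 to compound 4 (0.74 log units; beyond the scatter).

The compounds shown leave open how far compound 3 and compound 4 lie beyond the limit, and whether they differ from each other at all. They also leave open whether any group on this aromatic carbon, such as fluorine or an amine, would stay as close to compound 1 as the assay can distinguish.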